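Adding a second methoxy to compound 3

The compounds below may be only part of what the source reports. "The series", "measured", "known", "first", "only" and "open" are said of these compounds alone.

Measured in an ADME assay on MT4 cells (Homo sapiens) for cytotoxicity, read by MTT assay, with a stated time of 96 h; a lower number here means that less compound is tolerated, a higher number that more compound is tolerated 
- compound 1 `COc1ccc(-c2nc3cc(C(C)=O)ccc3n2C2CCCCC2)c(OC)c1` gives 21000 nM 
- compound 2 `C/C(=N\NC(N)=S)c1ccc2c(c1)nc(-c1ccc(Cl)cc1)n2C1CCCCC1` gives 17000 nM 
- compound 3 `COc1ccc(-c2nc3cc(/C(C)=N/NC(N)=S)ccc3n2C2CCCCC2)cc1` gives 39000 nM 

Compound 3 lies within the scatter of compound 1 and beyond the scatter of compound 2 (a 2.3-fold higher number from compound 2 to compound 3 (0.36 log units; beyond the scatter)). Compound 4 `COc1ccc(-c2nc3cc(/C(C)=N/NC(N)=S)ccc3n2C2CCCCC2)c(OC)c1` has methoxy in place of hydrogen on an aromatic carbon, turning 4-methoxyphenyl into 2,4-dimethoxyphenyl (methoxy in place of hydrogen on an aromatic carbon). Going by the values given here, the one measured step, a modest swap of chloro for methoxy, bears on this only loosely, and no measured step adds methoxy in place of hydrogen. Compound 1 also carries 2,4-dimethoxyphenyl and gives 21000 nM in this measurement. No step beyond the scatter is therefore expected in this assay in either direction. The expected step is small (a 1.3-fold lower number from compound 3 to compound 4 (0.11 log units; within the scatter)). For compound 4 the estimated value is 30000 nM with an expected range of 13000 nM to 70000 nM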

Compound 4, half-maximal cytotoxic concentration: 17000 nM
The estimate for compound 4 lay 1.8-fold (0.25 log units) above the measured number, and the stated range covers the measured number.
By their numbers in this assay, from the lowest: compounds 2, 4, 1 and 3 (each within the scatter of the next, the first and the last beyond it).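

In this assay, the first measured case of methoxy in place of hydrogen, here on an aromatic carbon ortho to a large group, turns 4-methoxyphenyl into 2,4-dimethoxyphenyl and gives a modest step (a 2.3-fold lower number from compound 3 to compound 4 (0.36 log units; beyond the scatter)). The new compound sits level with the 4-chlorophenyl compound (no change at the digits printed from compound 2 to compound 4 (within the scatter)) and with the carbonyl-bearing compound that shares its 2,4-dimethoxyphenyl (a 1.2-fold lower number from compound 1 to compound 4 (0.09 log units; within the scatter)). Nothing available explains the step.

Going by these compounds, whether fluoro, hydroxy or an amine at this place would move the number the same way stays open.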